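The source may report more compounds than this note shows. Statements on the series, on what has been measured and on what is new or still open speak of the compounds shown alone.

Measured so far in a functional assay on the whole organism (strain Wistar) for inhibition, with Rattus norvegicus as the target, with stated times of 30 min and 3 h, at a dose of 20 mg/kg by the oral route; on this read-out higher numbers stand for more inhibition at the one dose given (going by the name of the read-out) and lower numbers for less inhibition:
compound 1 `COc1ccc(/C=C2\C=C(c3ccc(Cl)cc3)OC2=O)cc1OC` — compound 1 gives 36%
compound 2 `O=C1/C(=C/c2ccccc2)C=C(c2ccc(Cl)cc2)N1Cc1ccccc1` — compound 2 gives 37%

Compound 2 and compound 1 lie within the usual scatter of each other in this assay, so these two numbers show no difference that can be trusted. Among the compounds with values here, no pair of measured compounds differs in a single place, so no step size is known for this series, and any expectation rests on the two values alone.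

Compound 3, `COc1cc(/C=C2\C=C(c3ccc(Cl)cc3)N(Cc3ccccc3)C2=O)ccc1O`, has not yet been measured. It differs from compound 2 in one place: 4-hydroxy-3-methoxyphenyl in place of phenyl on a double-bonded chain carbon bound to a double-bonded ring carbon. Within the data shown here, no measured pair shows what this change does, and compound 1, on a different core, offers no direct guide. A step in this assay within the scatter is expected, with no settled direction. Compound 3 is estimated at 38%, within 24% to 52%. The expected step is a number 1 percentage points higher from compound 2 to compound 3 (within the scatter).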

Compound 3, a percentage reported as inhibition, in the whole organism at one dose (the size of the read-out at that dose, not a potency): 42%
For compound 3 the middle estimate is 4 percentage points below the measured one; low and high end bracket the measured number.
By their numbers in this assay, from the lowest: compounds 1, 2 and 3 (each within the scatter of the next).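

Within the data shown here, the first single-place comparison reads, in this assay, as a number 5 percentage points higher from compound 2 to compound 3 (within the scatter) for 4-hydroxy-3-methoxyphenyl in place of phenyl on a double-bonded chain carbon bound to a double-bonded ring carbon. This position therefore accepts a larger group with a hydrogen-bond donor and hydrogen-bond acceptors, while the two compounds cannot be told apart at the one dose given. No measurement available here explains the size of this step.

Open, as far as these compounds go, is whether a single hydroxy or methoxy group on the phenyl ring would read the same as the combined 4-hydroxy-3-methoxyphenyl group. Also open, from the compounds shown here alone, is whether an amine, a carboxylic acid or a longer chain at this position would give a step beyond the scatter.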